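The source may report more compounds than this note shows. Statements on the series, on what has been measured and on what is new or still open speak of the compounds shown alone.

Measured compounds in a functional assay on MDA-MB-231 cells (Homo sapiens) for antiproliferative activity, read by MTT assay, with a stated time of 72 h; a lower number here means a stronger inhibitor, a higher number a weaker inhibitor:
Compound 1 `O=C(Nc1ccc(Cl)cc1)Nc1cccc(-c2nc(-c3ccc(NC(=O)c4cccnc4)cc3Cl)no2)c1`: > 10000 nM, a limit of the assay.
Compound 2 `C#Cc1cccc(NC(=O)Nc2cccc(-c3nc(-c4ccc(NC(=O)c5cccnc5)cc4Cl)no3)c2)c1`: > 10000 nM, a limit of the assay.
Compound 3 `CC(=O)Nc1ccc(NC(=O)Nc2cccc(-c3nc(-c4ccc(NC(=O)c5cccnc5)cc4Cl)no3)c2)cc1`: > 10000 nM, a limit of the assay.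

Compound 3 therefore stands only at a limit in this assay, as do the two other values, all sitting at the limit of > 10000 nM in this assay, at which 3 of the 3 values shown sit. Compound 4 `CC(=O)Nc1ccc(NC(=O)Nc2cccc(-c3nc(-c4ccc(NC(=O)c5cccnc5)cc4Cl)no3)c2)cc1Br` differs from compound 3 by bromo in place of hydrogen on an aromatic carbon. The measured steps a step that the two limits leave unreadable from compound 1 to compound 2, a step that the two limits leave unreadable from compound 1 to compound 3 and a step that the two limits leave unreadable from compound 2 to compound 3 are all unreadable, so none of them gives a readable size for a change on this ring. With compound 3 at a limit and no readable step, compound 4 is expected to show a step that the limit leaves unreadable from compound 3 to compound 4, and its estimated value is 20000 nM, within 5000 nM to 100000 nM.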

Compound 4, half-maximal inhibitory concentration: 1000 nM
The estimate for compound 4 lay 20-fold (1.30 log units) above the measured number; measured number below the stated range.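

In this assay, among these compounds, bromo in place of hydrogen, ortho to the acetamido group, gives an at least 10-fold lower number from compound 3 to compound 4 (1.00 log units; beyond the scatter), so this position can move the number, which no earlier step could show because those steps cannot be read. The 4-acetamido-3-bromophenyl group likewise gives an at least 10-fold lower number from compound 2 to compound 4 (1.00 log units; beyond the scatter) and an at least 10-fold lower number from compound 1 to compound 4 (1.00 log units; beyond the scatter). Only compound 4 leaves the limit shared by the other compounds: the limit of > 10000 nM in this assay, at which 3 of the 4 values shown sit.

Going by these compounds, whether chloro, methyl or methoxy at this position would give a similar step stays open. So does whether bromo would give it without the acetamido group.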